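A few compounds are considered here, and "the series" means these few. Any claim that something is new, unique, unknown or untested is made for them only; others in the source may bear on it.

Of the compounds shown here, three that share one core have been measured in an assay on HEK293 cells for inhibition of N-acylethanolamine-hydrolyzing acid amidase (Rattus norvegicus), read by LC-MS, with a stated time of 30 min; a higher number here means a weaker inhibitor, a lower number a stronger inhibitor. Compound 1, `O=C1OCCN1C(=O)c1ccc(Oc2ccccc2)cc1`, gives 680 nM. Compound 2, `Cc1cccc(Oc2ccc(C(=O)N3CCOC3=O)cc2)c1`, gives 5210 nM; the step of a 7.7-fold higher number from compound 1 to compound 2 (0.88 log units; beyond the scatter) is a methyl in place of hydrogen on an aromatic carbon. Compound 3, `O=C1OCCN1C(=O)c1ccc(OC2CCCCC2)cc1`, gives 92 nM, the lowest of the three numbers: the step of a 7.4-fold lower number from compound 1 to compound 3 (0.87 log units; beyond the scatter) puts cyclohexyl in place of phenyl on an oxygen on an aromatic ring, and the step of a 57-fold lower number from compound 2 to compound 3 (1.75 log units; beyond the scatter) puts cyclohexyl in place of 3-methylphenyl at the same place.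

Compound 4, `CCCCOc1ccc(C(=O)N2CCOC2=O)cc1`, differs from compound 3 in one place: butyl in place of cyclohexyl on an oxygen on an aromatic ring. Among the compounds with values here, none of the measured steps swaps a ring for a chain at that oxygen; the nearest guide is that the change from phenyl to cyclohexyl gave a modest gain, so the oxygen substituent does move this assay by modest amounts. Taking butyl as a departure from the cyclohexyl of compound 3, a modest step in this assay is expected for compound 4, more likely toward a higher number than a lower one, as a 2.4-fold higher number from compound 3 to compound 4 (0.38 log units; beyond the scatter). Compound 4 is therefore estimated at 220 nM, within 50 nM to 900 nM.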

Compound 4, half-maximal inhibitory concentration: 1340 nM
Compound 4: middle estimate off by 6.1-fold (0.78 log units), on the low side; measured number above the stated range.
By their numbers in this assay, from the lowest: compound 3; then compounds 1 and 4 (each within the scatter of the next); then compound 2.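

Butyl is the first open chain at this oxygen, and it shows that losing the aromatic ring is not enough to reach the number of compound 3: the step of a 15-fold higher number from compound 3 to compound 4 (1.16 log units; beyond the scatter) in this assay is large, so the gain seen with cyclohexyl does not carry over to every non-aromatic group here. Butyl also cannot be told apart from phenyl at this place, since the step of a 2.0-fold higher number from compound 1 to compound 4 (0.29 log units; within the scatter) stays small enough to leave the two compounds level, while the step of a 3.9-fold lower number from compound 2 to compound 4 (0.59 log units; beyond the scatter) shows that butyl still gives a lower number than 3-methylphenyl. No measurement shown here explains why the ring and the chain differ so much.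

Butyl differs from cyclohexyl in two ways at once, having fewer carbons and no ring, so these compounds cannot show which of the two differences matters. A hexyl chain would keep the carbon count of cyclohexyl without the ring, and a cyclobutyl ring would keep the carbon count of butyl with a ring, so either could begin to separate the two.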